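Swapping the benzyl aryl for a benzothiazole in a chromone series

The compounds below may be only part of what the source reports. "The series", "measured", "known", "first", "only" and "open" are said of these compounds alone.

Measured compounds:
`COc1ccccc1-c1cc(=O)c2c(O)cc(OCCCCN3CCN(C)CC3)c(OC)c2o1` compound 1, 2330 nM
`Cc1ccc(COc2cc(O)c3c(=O)cc(-c4ccccc4)oc3c2OCCCCN2CCN(C)CC2)cc1` compound 2, 5090 nM

Two compounds carry measured values in a functional assay on HepG2 cells (Homo sapiens) for cytotoxicity, read by MTT assay, with a stated time of 72 h; a higher number here means a weaker inhibitor, a lower number a stronger inhibitor. Compound 1 gives 2330 nM in this assay, and compound 2 gives 5090 nM. Of the two numbers, compound 2 has the higher one, and the gap to compound 1 lies beyond the usual scatter, so compound 2 is the weaker inhibitor of the pair.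

The next compound, `CN1CCN(CCCCOc2c(OCc3nc4ccccc4s3)cc(O)c3c(=O)cc(-c4ccccc4)oc23)CC1` compound 3, keeps the shared core of compound 2 and alters only the group on the benzylic carbon: 1,3-benzothiazol-2-yl in place of 4-methylphenyl on a saturated chain carbon bound to an oxygen on an aromatic ring. For the measured compounds named here, no measured pair in this set isolates that kind of change, so there is nothing to anchor the size of the step in this assay; the expectation can only be that the number stays close to that of compound 2, with no shift beyond the scatter expected in either direction.

Compound 3 is therefore estimated at 4000 nM in this assay, with a range from 1500 nM to 12000 nM. The step that this estimate means, a 1.3-fold lower number from compound 2 to compound 3 (0.10 log units; within the scatter), is expected to be small.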

Compound 3, half-maximal inhibitory concentration: 5440 nM
Compound 3: the middle estimate sits 1.4-fold (0.13 log units) below what was measured; the range from low to high includes it.
By their numbers in this assay, from the lowest: compound 1; then compounds 2 and 3 (each within the scatter of the next).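

In this assay, for the compounds shown here, placing 1,3-benzothiazol-2-yl in place of 4-methylphenyl on a saturated chain carbon bound to an oxygen on an aromatic ring gives a 1.1-fold higher number from compound 2 to compound 3 (0.03 log units; within the scatter), the first reading of any change at this position. The entering group adds a five-membered aromatic ring with 2 hetero atoms and brings 2 hydrogen-bond acceptors where the leaving group has 0, yet this single pair shows no separation in the cytotoxicity read-out, so here the position accepts one aryl group for the other without a measurable shift. No supporting evidence is available to explain this result.

The compounds shown leave open whether this holds for groups of a different kind at the same place, such as an amine or a carboxylic acid, since one exchange of two aromatic groups cannot define what the position tolerates. They also leave open whether a longer chain carrying the same 1,3-benzothiazol-2-yl would keep the number where it is, or whether the result carries over to other substitution on the shared core.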